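Chloro in Place of Hydrogen on Two Related Cores

A few compounds are considered here, and "the series" means these few. Any claim that something is new, unique, unknown or untested is made for them only; others in the source may bear on it.

Measured compounds:
compound 1 `CC(C)N(C(=S)SCc1oc2ccccc2c(=O)c1Cl)C(C)C` gives 23600 nM
compound 2 `CC(C)N(C(=S)SCc1cc(=O)c2ccccc2o1)C(C)C` gives a limit, > 40000 nM
compound 3 `CC(C)N(C(=S)SCc1coc2ccccc2c1=O)C(C)C` gives 7900 nM

Three compounds were tested in a functional assay on MDA-MB-435S cells (Homo sapiens) for antiproliferative activity, read by MTT assay, with a stated time of 72 h; on this read-out lower numbers stand for stronger inhibition and higher numbers for weaker inhibition. Compound 1 `CC(C)N(C(=S)SCc1oc2ccccc2c(=O)c1Cl)C(C)C` gives 23600 nM. For compound 2 `CC(C)N(C(=S)SCc1cc(=O)c2ccccc2o1)C(C)C` the assay reports only a limit, > 40000 nM, which is not a number (the limit of > 40000 nM in this assay, at which 1 of the 3 values shown sits). Compound 3 `CC(C)N(C(=S)SCc1coc2ccccc2c1=O)C(C)C` gives 7900 nM, the lower of the two numbers, with compound 1 standing beyond the scatter from it.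

Compound 2 and compound 3 have the same atoms joined differently; how the two cores differ is not broken down here.

From compound 2 to compound 1 the change is chloro in place of hydrogen on an aromatic carbon; it made the step of an at least 1.6-fold lower number from compound 2 to compound 1 (0.22 log units; that floor lies within the scatter), whose floor lies within the scatter. Compound 4 `CC(C)N(C(=S)SCc1coc2cc(Cl)ccc2c1=O)C(C)C`, not yet measured, differs from compound 3 by chloro in place of hydrogen on an aromatic carbon. The surroundings differ: in compound 1 the chloro sits on a six-membered aromatic ring with 1 oxygen, ortho to a group of 1 heavy atom, ortho to a large group, two atoms from the ring oxygen; in compound 4 it sits on a six-membered aromatic ring of carbon only. In both it is meta to a fused ring and para to a fused ring. It is the same kind of change, not the same change.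

Compound 4 is expected to give about 6000 nM in this assay, between 2500 nM and 15000 nM. That expectation rests on compound 3 with 7900 nM. As far as these compounds go, it rests too on the step of an at least 1.6-fold lower number from compound 2 to compound 1 (0.22 log units; that floor lies within the scatter), whose floor is within the scatter and whose true size is unknown. The expected step is a 1.3-fold lower number from compound 3 to compound 4 (0.12 log units; within the scatter).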

Compound 4, half-maximal inhibitory concentration: > 25000 nM
Compound 4 ended at the assay's limit (the forecaster's own chance of this, stated with the estimate: 5%); middle value at least 4.1-fold (0.61 log units) away from the limit.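

In this assay, chloro in place of hydrogen on an aromatic carbon brought an at least 3.1-fold higher number from compound 3 to compound 4 (0.50 log units; beyond the scatter), so the result on this core did not follow the direction of the earlier step. Set side by side, the two results do not agree, and the change cannot be carried from one core to the other as a single step of fixed size or direction: the same change on two cores in this assay, an at least 1.6-fold lower number (0.22 log units; that floor lies within the scatter) from compound 2 to compound 1 and an at least 3.1-fold higher number (0.50 log units; beyond the scatter) from compound 3 to compound 4, at least 5.3-fold (0.72 log units) apart, beyond the scatter of two such steps. This does not show the true size of either step, as compound 2 and compound 4 each stand at a limit of the assay rather than at a number, nor does it separate the effect of the core from that of the place, since the chloro has different surroundings in compound 1 and compound 4.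

The compounds shown leave open whether a fluoro, methyl or methoxy group on the same aromatic carbon would bring a step like the one to compound 4, and whether chloro on another carbon of that ring would do so. They also leave open whether either step would hold with a diethylamino group in place of the diisopropylamino group.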